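Replacing the aryl group on the saturated ring carbon

The source may hold more compounds than are shown below. What is called first, only, known or untested is meant among the compounds shown, and "the series" means these compounds.

Measured compounds in an assay on isolated protein for inhibition of serine protease 1 (Homo sapiens), tested at 100 uM; on this read-out higher numbers stand for more inhibition at the one concentration tested (going by the name of the read-out) and lower numbers for less inhibition:
Compound 1 `COc1ccc(C2Oc3ccccc3N(CCCCCN3C(C)CCCC3C)C2=O)cc1` gives 2.3%.
Compound 2 `CC1CCCC(C)N1CCCCCN1C(=O)C(c2ccc(Cl)c(Cl)c2)Oc2ccccc21` gives 14%.
Compound 3 `COc1ccc(C2Oc3ccccc3N(CCCCCN3C(C)CCCC3C)C2=O)cc1OC` gives 0%.

Compound 2 stands highest of these three numbers: the step of a number 11.7 percentage points higher from compound 1 to compound 2 (beyond the scatter) and the step of a number 14 percentage points lower from compound 2 to compound 3 (beyond the scatter) both lie beyond the scatter, while the step of a number 2.3 percentage points lower from compound 1 to compound 3 (within the scatter) does not. Compound 4 `C/N=C(/N)c1cccc(C2Oc3ccccc3N(CCCCCN3C(C)CCCC3C)C2=O)c1` differs from compound 2 at the same place: a group of 10 heavy atoms (8 carbon, 2 nitrogen; one six-membered aromatic ring of carbon only) in place of a group of 8 heavy atoms (6 carbon, 2 chlorine; one six-membered aromatic ring of carbon only), on a saturated ring carbon. Within the data shown here, the two steps that bear on this change, a number 11.7 percentage points higher from compound 1 to compound 2 (beyond the scatter) and a number 14 percentage points lower from compound 2 to compound 3 (beyond the scatter), were modest, so a modest shift in this assay is expected, though no measured step tells its direction for an entering group of this kind. Compound 4 is estimated at 45%, between 10% and 85%, a step of a number 31 percentage points higher from compound 2 to compound 4 (beyond the scatter).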

Compound 4, a percentage reported as inhibition, at one concentration (the size of the read-out at that concentration, not a potency): 32%
Compound 4: middle estimate off by 13 percentage points, on the high side; low and high end bracket the measured number.
By their numbers in this assay, from the lowest: compounds 3 and 1 (each within the scatter of the next); then compound 2; then compound 4.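

In this assay, the nitrogen-bearing aryl group on the saturated ring carbon gives a number 18 percentage points higher from compound 2 to compound 4 (beyond the scatter) and a number 29.7 percentage points higher from compound 1 to compound 4 (beyond the scatter) and a number 32 percentage points higher from compound 3 to compound 4 (beyond the scatter) against the three earlier aryl groups. This position therefore accepts a group with a double bond outside the aromatic ring and reads higher with it than with 3,4-dichlorophenyl, the best of the earlier groups. Among these compounds, it also yields the first large step. On these data alone, how a simple amine or a carboxylic acid would read in the same place stays open. Nothing measured here explains the rise.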